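The source may hold more compounds than are shown below. What is called first, only, known or untested is meant among the compounds shown, and "the series" means these compounds.

Measured compounds in an in vitro ADME assay on microsomes from liver (Homo sapiens) for metabolic stability; on this read-out lower numbers stand for a shorter-lived compound and higher numbers for a longer-lived compound:

- compound 1 `COc1ccc(-c2cc(-c3ccc(-n4cncn4)cc3)cnc2N)cn1`: 3.5 h
- compound 2 `COc1ccc(-c2cc(-c3ccc4cnn(C)c4c3)cnc2N)cn1`: 2.38 h
- compound 3 `COc1ccc(-c2cc(-c3cccc(C(N)=O)c3)cnc2N)cn1`: > 4.16 h, a limit of the assay rather than a number

Compound 1 holds the higher of the two numbers in this assay, but its nearest neighbour is compound 2 and the gap between them lies within the usual scatter, so the two read as equivalent. The value of compound 3 is a limit and not a number, as noted in the limit of > 4.16 h in this assay, at which 1 of the 3 values shown sits. Going by the values given here, no step between measured compounds differing in one place is available.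

Compound 4 `CNC(=O)c1ccc(-c2cnc(N)c(-c3ccc(OC)nc3)c2)cc1` is not yet measured in this assay. It differs from compound 1 by methylcarbamoyl in place of 1H-1,2,4-triazol-1-yl on an aromatic carbon. Among the compounds with values here, the data hold no measured step of this kind. In this assay compound 4 is expected to sit close to compound 1, with an estimated step of a 1.1-fold higher number from compound 1 to compound 4 (0.04 log units; within the scatter) that stays within the scatter. The estimate for compound 4 is 3.8 h, with a range from 2.2 h to 6.5 h.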

Compound 4, half-life: > 4.16 h
Compound 4: no number, only a limit; the forecaster's own chance of this, stated with the estimate: 35%; middle value at least 1.0-fold (0.03 log units) from the limit.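

In this assay, going by these compounds alone, methylcarbamoyl in place of 1H-1,2,4-triazol-1-yl on an aromatic carbon, para to a large group, gives an at least 1.1-fold higher number from compound 1 to compound 4 (0.07 log units; that floor lies within the scatter), the first step that can be read at a single place. At this place, then, a group with no ring can replace the five-membered aromatic ring without a drop in half-life beyond the scatter. The true size of the step is hidden, as compound 4 gives only a limit, and the top of the range now holds two compounds: the limit of > 4.16 h in this assay, at which 2 of the 4 values shown sit.

Going by these compounds, how far compound 4 lies beyond its floor remains open. Also open, on these data alone, is whether a carboxylic acid or a dimethylcarbamoyl group on the same aromatic carbon would keep the half-life of compound 4.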